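Naphthyl in Place of a Trifluoromethylphenyl: Reading Two Limits

The source may hold more compounds than are shown below. What is called first, only, known or untested is meant among the compounds shown, and "the series" means these compounds.

Compound 1 `Cc1cc(Cc2cccc(F)c2)c(=O)n(CC(=O)Nc2ccc(Br)cc2)n1` was tested in a functional assay on HL-60 cells (Homo sapiens), read by calcium flux; on this read-out higher numbers stand for an effect only at larger amounts of compound and lower numbers for an effect already at smaller amounts. In this assay compound 1 gives > 50000 nM, which is a limit of the assay and not a number. Compound 2 `Cc1cc(Cc2ccc(C(F)(F)F)cc2)c(=O)n(CC(=O)Nc2ccc(Br)cc2)n1` carries a 4-(trifluoromethyl)phenyl in place of the 3-fluorophenyl on a saturated chain carbon bound to an aromatic carbon. In this assay compound 2 gives > 50000 nM, again only a limit. The step that the two limits leave unreadable from compound 1 to compound 2 therefore cannot be read, and compound 2 stands where every value shown so far stands, at the limit of > 50000 nM in this assay, at which 2 of the 2 values shown sit.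

Compound 3 `Cc1cc(Cc2cccc3ccccc23)c(=O)n(CC(=O)Nc2ccc(Br)cc2)n1` differs from compound 2 by naphthalen-1-yl in place of 4-(trifluoromethyl)phenyl on a saturated chain carbon bound to an aromatic carbon. For the measured compounds named here, only one measured step bears on an exchange of this kind, the one from compound 1 to compound 2, and its size is hidden by the two limits. Nothing measured points to a readable step in this assay in either direction beyond the usual scatter. Compound 3 is therefore expected to give about 50000 nM, within 10000 nM to 250000 nM. The expected step is a number no higher from compound 2 to compound 3 (the limit leaves the size open), and most likely the assay will once more report only a limit.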

Compound 3, half-maximal effective concentration: > 50000 nM
Compound 3: a limit, no number; the forecaster's own chance of this, stated with the estimate: 80%; the middle value sits exactly at the limit.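

In this assay compound 3 gives > 50000 nM, again a limit of the assay and not a number. No step from compound 1 or compound 2 to compound 3 can therefore be read, and all three compounds sit at one place: the limit of > 50000 nM in this assay, at which 3 of the 3 values shown sit.

The compounds shown leave open whether 3-fluorophenyl, 4-(trifluoromethyl)phenyl and naphthalen-1-yl differ at all in their effect in this assay.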